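Working notes: amide variation against a cytotoxicity limit

This account rests on a few compounds, and the source may have more. Where it says the series, first, only, none or still open, it means among the compounds named here.

The series shares one core and varies the group on the amide carbonyl carbon. Compound 1 `CN(C)c1cc2[nH]c(C3CCCCC3)nc2cc1NC(=O)c1ccccc1` carries a phenyl amide. In an ADME assay on Vero cells (Chlorocebus sabaeus) for cytotoxicity, read by resazurin assay, with a stated time of 3 days (a lower number here means a stronger inhibitor, a higher number a weaker inhibitor), compound 1 gives > 100 ug/mL, which is a limit of the assay rather than a number. Compound 2 `CN(C)c1cc2[nH]c(C3CCCCC3)nc2cc1NC(=O)c1cccs1` carries thiophen-2-yl in place of phenyl on the carbonyl carbon. In this assay compound 2 gives > 100 ug/mL, again a limit. Compound 3 `COc1ccc(C(=O)Nc2cc3nc(C4CCCCC4)[nH]c3cc2N(C)C)cc1` carries 4-methoxyphenyl on the carbonyl carbon. In this assay compound 3 gives > 100 ug/mL, also a limit. Compound 3 thus stands at the assay limit, as do the other two, and none of the steps among the measured compounds can be sized: a step that the two limits leave unreadable from compound 1 to compound 2, a step that the two limits leave unreadable from compound 1 to compound 3 and a step that the two limits leave unreadable from compound 2 to compound 3 are all unreadable since (the limit of > 100 ug/mL in this assay, at which 3 of the 3 values shown sit).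

Compound 4 `CN(C)c1cc2[nH]c(C3CCCCC3)nc2cc1NC(=O)c1ccco1` is not yet measured. It differs from compound 3 as follows: furan-2-yl in place of 4-methoxyphenyl on a carbonyl carbon. The nearest comparable step, a step that the two limits leave unreadable from compound 2 to compound 3, was unreadable, so no direction or size can be drawn from the data; the three limits show only that the amide variants so far have not produced measurable cytotoxicity. The expected step is a step that the limit leaves unreadable from compound 3 to compound 4, namely none beyond the scatter. Compound 4 is accordingly expected to give 150 ug/mL, most likely reported again as a limit, within 70 ug/mL to 400 ug/mL.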

Compound 4, half-maximal inhibitory concentration: > 100 ug/mL
Compound 4: only a limit was reported; the forecaster's own chance of this, stated with the estimate: 85%; the middle value does not contradict the limit.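

In this assay compound 4 gives > 100 ug/mL, a limit and not a number. No step linking compound 4 with compound 1, compound 2 or compound 3 can be read, because all four sit at the same limit: the limit of > 100 ug/mL in this assay, at which 4 of the 4 values shown sit.

The compounds shown leave open how these four amides rank against one another in this assay, and whether any group on the carbonyl carbon would give a measurable value there.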